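Trimethoxyphenyl pyrazole chalcones: third methoxy on carbonyl side

A few compounds are considered here, and "the series" means these few. Any claim that something is new, unique, unknown or untested is made for them only; others in the source may bear on it.

Measured compounds:
compound 1 `COc1cc(-c2cc(/C=C/C(=O)c3ccc(N)cc3)[nH]n2)cc(OC)c1OC` 5390 nM
compound 2 `COc1ccc(C(=O)/C=C/c2cc(-c3cc(OC)c(OC)c(OC)c3)n[nH]2)cc1OC` 4990 nM

Among the compounds with values here, in a functional assay on U-251 cells (Homo sapiens) for inhibition, read by sulforhodamine B assay, with a stated time of 48 h (on this read-out higher numbers stand for lower toxicity in this test and lower numbers for higher toxicity in this test), compound 2 gives the lowest of the two numbers; the only neighbour, compound 1, lies within the scatter, so the two stand level. Within the data shown here, the single measured step, a 1.1-fold lower number from compound 1 to compound 2 (0.03 log units; within the scatter), bears only loosely on the next change. Compound 3 `COc1cc(C(=O)/C=C/c2cc(-c3cc(OC)c(OC)c(OC)c3)n[nH]2)cc(OC)c1OC` differs from compound 2 by methoxy in place of hydrogen on an aromatic carbon. No measured step adds a methoxy on this ring, and the one step shown did not move the number, so for compound 3 in this assay a step of a 1.0-fold higher number from compound 2 to compound 3 (0.00 log units; within the scatter) is expected, none beyond the scatter. Compound 3 is estimated at 5000 nM, between 1500 nM and 16000 nM.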

Compound 3, concentration lethal to 50% of the cells: 5670 nM
Compound 3: the middle estimate sits 1.1-fold (0.05 log units) below what was measured; low and high end bracket the measured number.
By their numbers in this assay, from the lowest: compounds 2, 1 and 3 (each within the scatter of the next).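

In this assay the third methoxy on the carbonyl side gives a 1.1-fold higher number from compound 2 to compound 3 (0.06 log units; within the scatter) and so shows that this aromatic carbon, ortho to a methoxy group, takes the added group without a step beyond the scatter. Both changes on this ring now leave compound 1, compound 2 and compound 3 level, with no exception among the three. No supporting data bear on why the number stays level. Open, as far as these compounds go, is whether a hydroxy group, a carboxylic acid or a longer alkoxy chain at this position would move the number beyond the scatter.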